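This account rests on a few compounds, and the source may have more. Where it says the series, first, only, none or still open, it means among the compounds named here.

Compound 1 `COc1ccccc1C(=O)NCc1ccc(CNS(=O)(=O)c2ccccc2)cc1` — 1 nM
Compound 2 `Cc1ccccc1C(=O)NCc1ccc(CNS(=O)(=O)c2ccccc2)cc1` — 1 nM
Compound 3 `O=C(NCc1ccc(CNS(=O)(=O)c2ccccc2)cc1)c1cccc(Cl)c1` — 1000 nM

In an assay on MDA-MB-231 cells for binding affinity to C-X-C chemokine receptor type 4 (Homo sapiens), read by immunofluorescence and microscopy, with stated times of 10 min and 30 min (on this read-out lower numbers stand for an effect already at smaller amounts and higher numbers for an effect only at larger amounts of compound), compound 1 gives 1 nM and compound 2 gives 1 nM; the step of no change at the digits printed from compound 1 to compound 2 (within the scatter) lies within the scatter. Compound 3, with 3-chlorophenyl on the carbonyl carbon, stands at 1000 nM, the highest of the three numbers, and both steps to it are large: a 1000-fold higher number from compound 1 to compound 3 (3.00 log units; beyond the scatter) and a 1000-fold higher number from compound 2 to compound 3 (3.00 log units; beyond the scatter).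

The next compound is compound 4 `O=C(NCc1ccc(CNS(=O)(=O)c2ccccc2)cc1)c1ccncc1`. It differs from compound 3 in one place: pyridin-4-yl in place of 3-chlorophenyl on a carbonyl carbon. Here 3-chlorophenyl leaves and pyridin-4-yl enters on the carbonyl carbon whose other neighbour is an amide-type nitrogen.

For the measured compounds named here, no measured step exchanges one ring for a ring with a hetero atom, so none speaks directly to this change. Going by the values given here, the steps from compound 1 and compound 2 to compound 3 show only that the group on the carbonyl carbon can move the number over a very wide span in this assay. The chlorine that leaves is what set compound 3 apart from the others, so a movement back toward lower numbers is the more likely direction, but its size is uncertain. The estimate for compound 4 is therefore 200 nM, with a range from 20 nM to 2000 nM, which means an expected step of a 5.0-fold lower number from compound 3 to compound 4 (0.70 log units; beyond the scatter).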

Compound 4, effective concentration (reported as EC, without a stated level of effect): 10 nM
The estimate for compound 4 lay 20-fold (1.30 log units) above the measured number, outside the stated range (below it).
By their numbers in this assay, from the lowest: compounds 1 and 2 (each within the scatter of the next); then compound 4; then compound 3.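

In this assay, the carbonyl carbon whose other neighbour is an amide-type nitrogen accepts a ring with a hetero atom: pyridin-4-yl in place of 3-chlorophenyl gives a 100-fold lower number from compound 3 to compound 4 (2.00 log units; beyond the scatter) and so recovers much of the span that separated compound 3 from the other compounds. The recovery is only partial, since the same group also gives a 10-fold higher number from compound 2 to compound 4 (1.00 log units; beyond the scatter) and a 10-fold higher number from compound 1 to compound 4 (1.00 log units; beyond the scatter) when it replaces 2-methylphenyl and 2-methoxyphenyl, so that this one position now yields three separate levels among four compounds. Nothing available explains why pyridin-4-yl falls short of those two groups yet far outperforms 3-chlorophenyl.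

The compounds shown leave open whether the high number of compound 3 comes from the chlorine itself or from where it sits on the ring, as compound 3 differs from compound 1 and compound 2 in both respects. They also leave open how the number would respond if an amine, a carboxylic acid or a longer chain stood on the carbonyl carbon in place of the aromatic ring.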